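The source may report more compounds than this note shows. Statements on the series, on what has been measured and on what is new or still open speak of the compounds shown alone.

Measured compounds:
compound 1 `c1ccc(COc2cccc(Nc3ncnc4cc5c(cc34)OCCOCCOCCO5)c2)cc1` — > 100000 nM in a functional assay on A549 cells (Homo sapiens) for antiproliferative activity, read by MTT assay, with a stated time of 72 h; on this read-out lower numbers stand for stronger inhibition and higher numbers for weaker inhibition (a limit)
compound 2 `FC(F)(F)c1ccc(COc2ccc(Nc3ncnc4cc5c(cc34)OCCOCCOCCOCCO5)cc2)cc1` — 8560 nM in this assay

Among the measured compounds shown here, only two compounds have numbers of any kind in this assay. Compound 1 reaches only the limit of the assay, > 100000 nM, so no number is known for it. For the measured compounds named here, compound 2 gives 8560 nM in this assay, the only true number in the set. The other entry belongs to compound 1 and is a limit (the limit of > 100000 nM in this assay, at which 1 of the 2 values shown sits). Compound 3 `c1ccc(COc2ccc(Nc3ncnc4cc5c(cc34)OCCOCCOCCOCCO5)cc2)cc1` has not yet been measured and differs from compound 2 in one place: hydrogen in place of trifluoromethyl on an aromatic carbon. Going by the values given here, no pair of measured compounds differs in just one place, so nothing measured sets the size of this step. The expectation is a loss of potency in this assay, a rise in concentration beyond the usual scatter, though not a large one. Compound 3 is expected to give about 20000 nM, in a range from 5000 nM to 100000 nM. The expected step of a 2.3-fold higher number from compound 2 to compound 3 (0.37 log units; beyond the scatter) is thus a moderate weakening.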

Compound 3, half-maximal inhibitory concentration: 29500 nM
For compound 3 the middle estimate is 1.5-fold (0.17 log units) below the measured one, within the range that was stated.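

Among the compounds shown here, the change from 4-(trifluoromethyl)benzyl to benzyl is the first single change with a measured size in this assay, and it gives a 3.4-fold higher number from compound 2 to compound 3 (0.54 log units; beyond the scatter). This shows that the group at this place on the ring affects the read-out, and that trifluoromethyl gives stronger inhibition than hydrogen here, though only modestly, since compound 3 still gives a true number of 29500 nM. No measurement shown here explains the size of this step.

Going by these compounds, it remains open whether fluorine, chlorine, a methoxy group or a nitrile at this same place would match trifluoromethyl, fall short of it or surpass it. On these data alone, it is also open whether the same change would give a step of similar size on a compound with a shorter chain in the large ring of the core.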